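Working notes: pyrimidin-2-yl in place of methyl

The source may report more compounds than this note shows. Statements on the series, on what has been measured and on what is new or still open speak of the compounds shown alone.

- Compound 1 `c1ccc(/N=N/N2CCN(c3ccccc3)CC2)cc1` gives 33000 nM
- Compound 2 `CN1CCN(/N=N/c2ccccc2)CC1` gives 65000 nM

Among the measured compounds shown here, in an ADME assay on MT4 cells (Homo sapiens) for cytotoxicity, read by MTT assay, with a stated time of 96 h (on this read-out higher numbers stand for lower toxicity in this test and lower numbers for higher toxicity in this test), compound 2 cannot be told apart from compound 1, the only other measured member of the series. The next compound is compound 3 `c1ccc(/N=N/N2CCN(c3ncccn3)CC2)cc1`, with the change pyrimidin-2-yl in place of methyl on an amine nitrogen in a ring. For the measured compounds named here, the one measured step at this nitrogen, a 2.0-fold higher number from compound 1 to compound 2 (0.29 log units; within the scatter), is methyl in place of phenyl, so no step beyond the scatter is expected in this assay. The estimate for compound 3 is 40000 nM, with an expected range from 16000 nM to 90000 nM. That is an expected 1.6-fold lower number from compound 2 to compound 3 (0.21 log units; within the scatter).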

Compound 3, half-maximal cytotoxic concentration: 90000 nM
Compound 3: middle estimate off by 2.3-fold (0.35 log units), on the low side; low and high end bracket the measured number.
By their numbers in this assay, from the lowest: compounds 1, 2 and 3 (each within the scatter of the next, the first and the last beyond it).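

In this assay, among the compounds shown here, pyrimidin-2-yl in place of phenyl on the amine nitrogen gives a 2.7-fold higher number from compound 1 to compound 3 (0.44 log units; beyond the scatter) and so the first step at this position beyond the scatter, though a modest one. Pyrimidin-2-yl in place of methyl gives a 1.4-fold higher number from compound 2 to compound 3 (0.14 log units; within the scatter) and stays within the scatter, so at this nitrogen only the pair of pyrimidin-2-yl and phenyl separates. No available evidence bears on this result. Open, from the compounds shown here alone, is whether a pyridin-2-yl group on this nitrogen reads with phenyl or with pyrimidin-2-yl, and how a longer chain or a carboxylic acid there would read.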